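Swapping the anilide ring of compound 3 for a cyclohexyl

This account rests on a few compounds, and the source may have more. Where it says the series, first, only, none or still open, it means among the compounds named here.

Compound 3 `Cc1ccc(S(=O)(=O)/N=C(/CCNC2=CC(=O)c3ccccc3C2=O)Nc2ccc(Cl)cc2Cl)cc1` is one of three compounds tested in a functional assay on A549 cells (Homo sapiens) for cytotoxicity, read by MTT assay, with a stated time of 48 h (on this read-out higher numbers stand for weaker inhibition and lower numbers for stronger inhibition), together with compound 1 `COc1ccc(N/C(CCNC2=CC(=O)c3ccccc3C2=O)=N\S(=O)(=O)c2ccc(C)cc2)cc1` and compound 2 `Cc1ccc(S(=O)(=O)/N=C(/CCNC2=CC(=O)c3ccccc3C2=O)Nc2ccccc2[N+](=O)[O-])cc1`. In this assay compound 3 gives 32900 nM, the highest of the three numbers; compound 1 gives 25500 nM, and the step of a 1.3-fold higher number from compound 1 to compound 3 (0.11 log units; within the scatter) lies within the scatter, so the two cannot be ranked. Compound 2 gives 5010 nM, and the step of a 6.6-fold higher number from compound 2 to compound 3 (0.82 log units; beyond the scatter) is modest but real. Compound 4 `Cc1ccc(S(=O)(=O)/N=C(/CCNC2=CC(=O)c3ccccc3C2=O)NC2CCCCC2)cc1` differs from compound 3 by cyclohexyl in place of 2,4-dichlorophenyl on an amine nitrogen. Within the data shown here, every measured step exchanges one aromatic ring for another aromatic ring; none exchanges an aromatic ring for a saturated one, so no step bears directly on this change. The estimate for compound 4 is therefore 25000 nM, between 8000 nM and 80000 nM, which is expected to be a step of a 1.3-fold lower number from compound 3 to compound 4 (0.12 log units; within the scatter), within the scatter.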

Compound 4, half-maximal inhibitory concentration: 14700 nM
For compound 4 the middle estimate is 1.7-fold (0.23 log units) above the measured one; the range from low to high includes it.
By their numbers in this assay, from the lowest: compound 2; then compounds 4, 1 and 3 (each within the scatter of the next, the first and the last beyond it).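

In this assay a saturated ring can stand on this amine nitrogen without leaving the range set by the aromatic rings: the change gives a 2.2-fold lower number from compound 3 to compound 4 (0.35 log units; beyond the scatter) and a 2.9-fold higher number from compound 2 to compound 4 (0.47 log units; beyond the scatter) and, with no ranking possible, a 1.7-fold lower number from compound 1 to compound 4 (0.24 log units; within the scatter) as the third comparison. Cyclohexyl thus sits among the aromatic groups, and the aromatic ring itself is not required for a measurable number here. Nothing measured offers a reason for these steps. From the compounds shown here alone, how a cyclopentyl ring, an open hexyl chain or a cyclohexyl ring bearing an amine would behave at this position remains open.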